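Replacing the aromatic group of compound 3

This account rests on a few compounds, and the source may have more. Where it says the series, first, only, none or still open, it means among the compounds named here.

Within the data shown here, in an ADME assay on a cell-free system (plasma, Mus musculus) for metabolic stability, read by LC-MS, tested at 2 uM (on this read-out lower numbers stand for a shorter-lived compound and higher numbers for a longer-lived compound), compound 1 `CCOCCNC(=O)n1cc(-c2ccccc2)oc1=O` gives 1.33 h, the only exact number so far. Compound 2 `COc1cccc(-c2cn(C(=O)NCCCCc3ccccc3)c(=O)o2)c1` gives only a limit, > 2 h. Compound 3 `COc1cc(-c2cn(C(=O)NCCCCc3ccccc3)c(=O)o2)ccc1F` also gives only a limit, > 2 h. It therefore stands at the limit of > 2 h in this assay, at which 2 of the 3 values shown sit. Among the measured compounds shown here, the one measured step is a step that the two limits leave unreadable from compound 2 to compound 3, so it offers no size to carry forward, and it concerns a different change. Compound 4 `O=C(NCCCCc1ccccc1)n1cc(-c2ccncc2)oc1=O` brings (pyridin-4-yl in place of 4-fluoro-3-methoxyphenyl on an aromatic carbon), with pyridin-4-yl in place of 4-fluoro-3-methoxyphenyl. For the measured compounds named here, no measured step covers this swap, so no particular direction is expected, and the expected move is small: a number no higher from compound 3 to compound 4 (the limit leaves the size open). For compound 4 the estimated half-life is 2 h, within an expected range from 1 h to 4 h.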

Compound 4, half-life: 0.5 h
Beside the measured number, compound 4's estimate is 4.0-fold (0.60 log units) above it; the whole stated range lies above it.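

Measured in this assay on this carbon next to the ring oxygen, the swap to pyridin-4-yl gives an at least 4.0-fold lower number from compound 3 to compound 4 (0.60 log units; beyond the scatter) and an at least 4.0-fold lower number from compound 2 to compound 4 (0.60 log units; beyond the scatter) as its two steps. Compound 2 and compound 3 alone could not show that the aromatic group here changes the half-life at all. Both steps give only a minimum size, since each starts from a limit: the limit of > 2 h in this assay, at which 2 of the 4 values shown sit.

From the compounds shown here alone, whether the ring nitrogen or the absence of the phenyl substituents matters most stays open. A plain phenyl or a pyridin-3-yl group in this place, with the rest of compound 4 kept, would help separate the two.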